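A Hydroxy Group Added to Compound 1

The compounds below may be only part of what the source reports. "The series", "measured", "known", "first", "only" and "open" are said of these compounds alone.

Measured so far in a functional assay on P388 cells (Mus musculus) for cytotoxicity; a higher number here means that more compound is needed for the effect, a lower number that less compound is needed:
- compound 1 `C/C1=C/[C@H](O)C/C(C)=C/[C@H](O)C(=O)/C(C)=C/[C@H]2[C@@H](CC1)C2(C)C` gives 1.4 ug/mL
- compound 2 `C/C1=C/C(=O)C/C(C)=C/[C@H](O)C(=O)/C(C)=C/[C@H]2[C@@H](CC1)C2(C)C` gives 2.8 ug/mL

Among the compounds with values here, only two numbers exist so far, and they lie within the usual scatter of each other, so compound 1 stands level with compound 2 in this assay and neither can be ranked. Compound 3 `C/C1=C/[C@H](O)C/C(C)=C/[C@H](O)C(=O)/C(C)=C/[C@H]2[C@@H](CC1)[C@]2(C)CO` has not been measured. Within the data shown here, it keeps the core of compound 1 but carries hydroxy in place of hydrogen on a saturated chain carbon bound to a saturated ring carbon as its only change. Among the measured compounds shown here, no measured pair shows what this change does, so any forecast is loose. A small rise in the number is expected in this assay and may stay within the scatter. The expected step is a 1.8-fold higher number from compound 1 to compound 3 (0.25 log units; within the scatter) on this estimate. For compound 3 the estimated value is 2.5 ug/mL with an expected range from 0.7 ug/mL to 9 ug/mL for a single measurement.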

Compound 3, concentration for half-maximal effect: 0.8 ug/mL
Compound 3: the middle estimate sits 3.1-fold (0.49 log units) above what was measured; the range from low to high includes it.
By their numbers in this assay, from the lowest: compounds 3, 1 and 2 (each within the scatter of the next, the first and the last beyond it).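

Placing hydroxy in place of hydrogen on a saturated chain carbon bound to a saturated ring carbon gives a 1.8-fold lower number from compound 1 to compound 3 (0.24 log units; within the scatter) in this assay. Within the data shown here, this is the first measured look at this position, and it shows that the added hydroxy leaves compound 3 level with compound 1 in this assay, so the position accepts this small group without a loss that can be told from the scatter. No available evidence bears on this result.

From the compounds shown here alone, whether a methoxy, an amine or a carboxylic acid on this same carbon would also leave the number level remains open. Also open, going by these compounds, is whether the same hydroxy would behave alike on compound 2, which carries a carbonyl elsewhere on the shared core.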